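Fluoro to chloro on a shared core

The compounds below may be only part of what the source reports. "The series", "measured", "known", "first", "only" and "open" are said of these compounds alone.

Values in a functional assay on HL-60 cells (Homo sapiens) for cytotoxicity, read by WST assay, with a stated time of 48 h; a higher number here means that more compound is needed for the effect, a lower number that less compound is needed:
Compound 1 `O=C1OC[C@H](Cc2cccc(F)c2)[C@H]1Cc1ccc(Cl)c(Cl)c1`: 14000 nM
Compound 2 `O=C1OC[C@H](Cc2ccc(F)cc2)[C@H]1Cc1ccc(Cl)c(Cl)c1`: 14000 nM
Compound 3 `O=C1OC[C@H](Cc2ccc(F)c(F)c2)[C@H]1Cc1ccc(Cl)c(Cl)c1`: 25000 nM

Compound 3, at 25000 nM, lies within the scatter of the other two compounds. Compound 4 `O=C1OC[C@H](Cc2ccc(Cl)c(Cl)c2)[C@H]1Cc1ccc(Cl)c(Cl)c1` carries 3,4-dichlorophenyl in place of 3,4-difluorophenyl on a saturated chain carbon bound to a saturated ring carbon. Within the data shown here, no measured step swaps fluoro for chloro. The nearest evidence is small: no change at the digits printed from compound 1 to compound 2 (within the scatter), a 1.8-fold higher number from compound 1 to compound 3 (0.25 log units; within the scatter) and a 1.8-fold higher number from compound 2 to compound 3 (0.25 log units; within the scatter). No change beyond the scatter is therefore expected in this assay, and no direction can be favoured. The expected step is a 1.6-fold lower number from compound 3 to compound 4 (0.19 log units; within the scatter). For compound 4 the estimated value is 16000 nM, with an expected range from 6000 nM to 40000 nM.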

Compound 4, half-maximal effective concentration: 20000 nM
Beside the measured number, compound 4's estimate is 1.3-fold (0.10 log units) below it, within the range that was stated.
By their numbers in this assay, from the lowest: compounds 1, 2, 4 and 3 (each within the scatter of the next).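

In this assay, chloro on both ring positions gives a 1.3-fold lower number from compound 3 to compound 4 (0.10 log units; within the scatter) and so shows that this position accepts chlorine as well as fluorine. The earlier compounds shown here carried fluoro only and could not show this. The other two comparisons, a 1.4-fold higher number from compound 2 to compound 4 (0.15 log units; within the scatter) and a 1.4-fold higher number from compound 1 to compound 4 (0.15 log units; within the scatter), also stay inside the scatter, so all four groups at this place read alike.

Going by these compounds, whether an amine or a carboxylic acid on this ring, or a longer chain, would move the number beyond the scatter stays open. Nothing here offers an explanation for this flat result.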